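This account rests on a few compounds, and the source may have more. Where it says the series, first, only, none or still open, it means among the compounds named here.

In a functional assay on RKOp27 cells (Homo sapiens) for cytotoxicity, read by MTT assay, with a stated time of 3 days (on this read-out lower numbers stand for stronger inhibition and higher numbers for weaker inhibition), compound 1 (`N#Cc1c(-c2ccccc2)nc(SCc2nc3ccccc3[nH]2)nc1N1CCNCC1`) gives 5.81 nM and compound 2 (`N#Cc1c(-c2ccccc2)nc(SCc2nc3ccccc3[nH]2)nc1N1CCN(S(=O)(=O)c2ccccc2)CC1`) gives 7.35 nM so the two stand within the scatter of each other. Compound 3 (`Cc1ccc(S(=O)(=O)N2CCN(c3nc(SCc4nc5ccccc5[nH]4)nc(-c4ccccc4)c3C#N)CC2)cc1`) differs from compound 2 by methyl in place of hydrogen on an aromatic carbon in one place: methyl in place of hydrogen on an aromatic carbon, turning phenylsulfonyl to (4-methylphenyl)sulfonyl. Within the data shown here, no measured step tests this methyl directly. The nearest is a 1.3-fold higher number from compound 1 to compound 2 (0.10 log units; within the scatter) for phenylsulfonyl in place of hydrogen on an amine nitrogen in a ring, so no step beyond the scatter is expected in either direction. The estimate amounts to a 1.0-fold higher number from compound 2 to compound 3 (0.01 log units; within the scatter) as the expected step. Compound 3 has an estimated value of 7.5 nM (expected range 3.5 nM to 16 nM).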

Compound 3, half-maximal inhibitory concentration: 2.5 nM
Beside the measured number, compound 3's estimate is 3.0-fold (0.48 log units) above it; measured number below the stated range.
By their numbers in this assay, from the lowest: compound 3; then compounds 1 and 2 (each within the scatter of the next).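

In this assay, one methyl on the aromatic ring of the phenylsulfonyl group gives a 2.9-fold lower number from compound 2 to compound 3 (0.47 log units; beyond the scatter), so this outer ring responds to a very small change, something the earlier pair could not show. The full (4-methylphenyl)sulfonyl group in place of the amine hydrogen gives a 2.3-fold lower number from compound 1 to compound 3 (0.37 log units; beyond the scatter), whereas phenylsulfonyl alone produced no step beyond the scatter. No measurement here accounts for this gain.

Going by these compounds, whether the gain is specific to methyl remains open. An ethyl, methoxy or amino group at the same place would help test this.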